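This account rests on a few compounds, and the source may have more. Where it says the series, first, only, none or still open, it means among the compounds named here.

Measured compounds in a functional assay on HCT-116 cells (Homo sapiens) for inhibition, read by MTT assay, with a stated time of 72 h; on this read-out lower numbers stand for stronger inhibition of growth and higher numbers for weaker inhibition of growth:
compound 1, `Cc1cc(CN2CCN(c3c(Br)cnc4[nH]c(-c5ccc(CN)cc5)nc34)CC2)no1`; compound 1 gives 240 nM
compound 2, `CN(C)Cc1ccc(-c2nc3c(N4CCN(CC(=O)Nc5nccs5)CC4)c(Br)cnc3[nH]2)cc1`; compound 2 gives 1000 nM
compound 3, `COc1ccc(-c2nc3c(N4CCN(Cc5cc(C)on5)CC4)c(Br)cnc3[nH]2)cc1`; compound 3 gives 540 nM

Compound 3 stands second highest of the three numbers. Its nearest neighbour is compound 2, whose number lies within the scatter of that of compound 3, so no order between the two is claimed. Among the measured compounds shown here, the only single-point step among the measured compounds runs from compound 1 to compound 3: a 2.3-fold higher number from compound 1 to compound 3 (0.35 log units; beyond the scatter).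

Compound 4, `Cc1cc(CN2CCN(c3c(Br)cnc4[nH]c(-c5ccc(CN(C)C)cc5)nc34)CC2)no1`, is not yet measured in this assay. It differs from compound 3 as follows: (dimethylamino)methyl in place of methoxy on an aromatic carbon. The step from compound 1 to compound 3 bears on this change: there too the group on the aromatic carbon was exchanged between methoxy and a group carrying an amine, and that step was modest and raised the number. Compound 2 also carries (dimethylamino)methyl on the aromatic carbon, but it differs from compound 3 in a second place as well, so its number alone settles nothing. The expectation below roughly undoes the step from compound 1 to compound 3. For compound 4 a modest lowering of the number is therefore expected: a 1.8-fold lower number from compound 3 to compound 4 (0.26 log units; within the scatter). The estimate for compound 4 is 300 nM, with a range from 120 nM to 750 nM.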

Compound 4, concentration for 50% growth inhibition: 230 nM
The estimate for compound 4 lay 1.3-fold (0.12 log units) above the measured number; the measured number falls inside the stated range.
By their numbers in this assay, from the lowest: compounds 4 and 1 (each within the scatter of the next); then compounds 3 and 2 (each within the scatter of the next).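

In this assay, (dimethylamino)methyl in place of methoxy on the aromatic carbon para to a large group gives a 2.3-fold lower number from compound 3 to compound 4 (0.37 log units; beyond the scatter), so a second amine-carrying group at this place stands on the same side of methoxy as aminomethyl, while dimethylamino in place of amino on the saturated chain carbon bound to an aromatic carbon gives a 1.0-fold lower number from compound 1 to compound 4 (0.02 log units; within the scatter), and no order is claimed for that pair. Among the compounds shown here, with (dimethylamino)methyl held constant, 5-methyl-1,2-oxazol-3-yl in place of (1,3-thiazol-2-yl)carbamoyl on the saturated chain carbon bound to an amine nitrogen in a ring gives a 4.3-fold lower number from compound 2 to compound 4 (0.64 log units; beyond the scatter), the first single-place reading of that part of the series. Nothing at hand gives a reason for either step.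

Open, on these data alone, is how a morpholin-4-ylmethyl group, a longer chain between the aromatic ring and the amine, or a carboxylic acid at this place would read in this assay. Also open is whether the step from methoxy to (dimethylamino)methyl keeps its size with (1,3-thiazol-2-yl)carbamoyl in the other place, since the compounds shown pair that group only with (dimethylamino)methyl.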